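Replacing 4-cyano-1H-pyrazol-1-yl on an Aromatic Carbon

The compounds below may be only part of what the source reports. "The series", "measured", "known", "first", "only" and "open" are said of these compounds alone.

Of the compounds shown here, three sharing one core have been measured in a physicochemical assay for lipophilicity, using the shake flask method, at pH 7.4; on this read-out higher numbers stand for higher lipophilicity and lower numbers for lower lipophilicity: compound 1 (`CCCC(Oc1ccc(-n2cc(OC)cn2)cc1)c1ccc(C(=O)NCCC(=O)O)cc1`) gives 1.4, compound 2 (`CCCC(Oc1ccc(-n2cc(C(=O)N(C)C)cn2)cc1)c1ccc(C(=O)NCCC(=O)O)cc1`) gives 0.5, and compound 3 (`CCCC(Oc1ccc(-n2cc(C#N)cn2)cc1)c1ccc(C(=O)NCCC(=O)O)cc1`) gives 1.2. Cyano in place of methoxy is a number 0.20 log units lower from compound 1 to compound 3 (within the scatter), while cyano in place of dimethylcarbamoyl is a number 0.70 log units higher from compound 2 to compound 3 (beyond the scatter). That leaves compound 3 level with compound 1 and clear of compound 2, second of the three numbers.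

Compound 4 (`CCCC(Oc1ccc(-n2cc3c(n2)CCCC3)cc1)c1ccc(C(=O)NCCC(=O)O)cc1`) changes a larger piece of the structure: a group of 9 heavy atoms (7 carbon, 2 nitrogen; one five-membered aromatic ring with 2 hetero atoms, one six-membered non-aromatic ring of carbon only) in place of a group of 7 heavy atoms (4 carbon, 3 nitrogen; one five-membered aromatic ring with 2 hetero atoms), on an aromatic carbon. Going by the values given here, no measured step makes this exchange, so the evidence is only indirect. The entering group counts more carbon and fewer hydrogen-bond acceptors, and on that count a rise is expected, roughly matching in size the step to compound 2, which was a number 0.90 log units lower from compound 1 to compound 2 (beyond the scatter). In this assay the expected change is a number 0.80 log units higher from compound 3 to compound 4 (beyond the scatter). The estimated value for compound 4 is 2, with an expected range from 1.6 to 2.5.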

Compound 4, distribution coefficient: 2.7
Compound 4: the middle estimate sits 0.70 log units below what was measured, outside the stated range (above it).
By their numbers in this assay, from the lowest: compound 2; then compounds 3 and 1 (each within the scatter of the next); then compound 4.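

In this assay, putting the group with the six-membered carbon ring in place of 4-cyano-1H-pyrazol-1-yl gives a number 1.50 log units higher from compound 3 to compound 4 (beyond the scatter) and places compound 4 clearly above every other compound shown. The same exchange gives a number 1.30 log units higher from compound 1 to compound 4 (beyond the scatter) against the methoxy group and a number 2.20 log units higher from compound 2 to compound 4 (beyond the scatter) against the dimethylcarbamoyl group, so this position, para to a large group, can shift the read-out upward by more than the earlier largest step, a number 0.90 log units lower from compound 1 to compound 2 (beyond the scatter) and its reverse, had suggested. Nothing available explains why the rise is this large.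

The exchange alters several atoms at once, so the share of the added carbon ring and the share of the lost nitrile cannot be separated. An open propyl chain or an amine on the same five-membered ring would help to tell these apart.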